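Working notes: dithiocarbamate amide series, carbonyl substituent extension

A few compounds are considered here, and "the series" means these few. Any claim that something is new, unique, unknown or untested is made for them only; others in the source may bear on it.

Three members of the series have numbers in a functional assay on SMMC-7721 cells (Homo sapiens) for cytotoxicity, read by MTT assay, with a stated time of 72 h; a higher number here means a weaker inhibitor, a lower number a stronger inhibitor. Compound 1 `O=C(CSC(=S)N[C@H]1CCOC1=O)Nc1ccc(Cl)cc1` reaches only a limit of the assay, reported as > 128000 nM. Compound 2 `CCOC(=O)c1ccc(NC(=O)CSC(=S)N[C@H]2CCOC2=O)cc1` gives 64900 nM in this assay, and compound 3 `CCCCc1ccc(NC(=O)CSC(=S)N[C@H]2CCOC2=O)cc1` gives 27300 nM. Of the two numbers shown, compound 2 carries the higher one; its nearest neighbour is compound 3, separated by a 2.4-fold lower number from compound 2 to compound 3 (0.38 log units; beyond the scatter). Compound 1 contributes only a limit. The remaining steps, an at least 1.9-fold lower number from compound 1 to compound 2 (0.29 log units; that floor lies within the scatter) and an at least 4.6-fold lower number from compound 1 to compound 3 (0.67 log units; beyond the scatter), likewise exchange the group on the aromatic carbon.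

Compound 4 `O=C(CSC(=S)N[C@H]1CCOC1=O)Nc1ccc(C(=O)/C=C/c2ccc(Cl)cc2)cc1` differs from compound 2 by 2-(4-chlorophenyl)ethenyl in place of ethoxy on a carbonyl carbon. Within the data shown here, none of the measured steps touches this carbonyl substituent; all three vary the aromatic substituent, and the largest of them, an at least 4.6-fold lower number from compound 1 to compound 3 (0.67 log units; beyond the scatter), was at least modest, while a 2.4-fold lower number from compound 2 to compound 3 (0.38 log units; beyond the scatter) was modest. By analogy only a small to modest step is expected in this assay, with no firm direction, and the expected step from compound 2 is a 1.9-fold lower number from compound 2 to compound 4 (0.27 log units; within the scatter). Compound 4 is therefore estimated at 35000 nM, within a range of 9000 nM to 130000 nM.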

Compound 4, half-maximal inhibitory concentration: > 128000 nM
Compound 4 was reported as a limit (the forecaster's own chance of this, stated with the estimate: 20%); at least 3.6-fold (0.56 log units) between middle value and limit.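

Among these compounds, this is the first change at the carbonyl substituent, with the aromatic position no longer the one varied: in this assay, the exchange gives an at least 1.9-fold higher number from compound 2 to compound 4 (0.29 log units; that floor lies within the scatter). The printed floor of that step lies within the scatter, so the data show no gain from the larger group, with its aromatic ring and extra double bond, but they do not establish a loss beyond the scatter either. The reading for compound 4 is a limit and not a number, so the true size of the step cannot be fixed, and this position is marked only by one bounded step: the limit of > 128000 nM in this assay, at which 2 of the 4 values shown sit.

The compounds shown leave open whether the chlorine, the aromatic ring or the double bond of 2-(4-chlorophenyl)ethenyl goes with this limit reading, as none of these parts is varied alone at the carbonyl carbon. Also open, on these data alone, is how a carboxylic acid, an amide formed with a simple amine, or a longer alkoxy chain in place of ethoxy would read in this assay, and whether any group at this carbonyl carbon can move the number lower than compound 2 gives.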